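The compounds below may be only part of what the source reports. "The series", "measured", "known", "first", "only" and "open" are said of these compounds alone.

In a functional assay on NCI-H441 cells (Homo sapiens) for antiproliferative activity, with a stated time of 24 h (on this read-out lower numbers stand for stronger inhibition and higher numbers for weaker inhibition), compound 1 (`O=C1C(Cc2ccccc2F)CNCC1Cc1ccccc1F`) gives 130000 nM, and compound 2 (`O=C(O)COCC(=O)N1C/C(=C\c2ccccc2F)C(=O)/C(=C/c2ccccc2F)C1`) gives 310000 nM. Compound 2 thus holds the higher of the two numbers, the weaker inhibition of the pair, and its gap to compound 1 lies beyond the usual scatter. Compound 3 (`Cc1ccc(S(=O)(=O)N2C/C(=C\c3ccccc3F)C(=O)/C(=C/c3ccccc3F)C2)cc1`) has yet to be measured. It departs from compound 2 at a single place, with (4-methylphenyl)sulfonyl in place of ((carboxymethoxy)methyl)carbonyl on an amine nitrogen in a ring. Among the compounds with values here, no measured pair differing in one place is available as a guide, so the expectation remains a judgement from the structural change alone. A clear step toward a lower number, beyond the scatter, is expected in this assay. The estimated step is a 26-fold lower number from compound 2 to compound 3 (1.41 log units; beyond the scatter). Compound 3 is expected at 12000 nM, within an estimated range of 2000 nM to 70000 nM.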

Compound 3, half-maximal inhibitory concentration: 50000 nM
For compound 3 the middle estimate is 4.2-fold (0.62 log units) below the measured one, and the stated range covers the measured number.
By their numbers in this assay, from the lowest: compound 3; then compound 1; then compound 2.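

In this assay, within the data shown here, the amine nitrogen in the ring proves sensitive to its substituent: (4-methylphenyl)sulfonyl in place of ((carboxymethoxy)methyl)carbonyl brings a 6.2-fold lower number from compound 2 to compound 3 (0.79 log units; beyond the scatter) and thus gives the first one-place comparison. The change removes a chain with no ring and one hydrogen-bond donor and introduces a six-membered aromatic ring with no donor, so this single pair cannot assign the step to any one part of the exchange. No available measurement accounts for the step.

The compounds shown leave open whether the step follows from the sulfonyl link, the aromatic ring or the loss of the carboxylic acid. A benzoyl or methylsulfonyl group on the same nitrogen could separate these parts, and a phenylsulfonyl group could test the methyl.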